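Replacing the Hydroxy of Compound 3

A few compounds are considered here, and "the series" means these few. Any claim that something is new, unique, unknown or untested is made for them only; others in the source may bear on it.

In a functional assay on HL-60 cells (Homo sapiens) for antiproliferative activity (a higher number here means a weaker inhibitor of growth, a lower number a stronger inhibitor of growth), compound 1 (`COCCCCCCCCCCCCCCC/C=C1\CC(CO)(COC(=O)C(C)(C)C)OC1=O`) gives 4.65 ug/mL and compound 2 (`CCCCCOCCCCCCC/C=C1\CC(CO)(COC(=O)C(C)(C)C)OC1=O`) gives 2.96 ug/mL, and the two are separated by a 1.6-fold lower number from compound 1 to compound 2 (0.20 log units; within the scatter). Compound 3 (`CC(C)(C)C(=O)OCC1(CO)C/C(=C\CCCCCCCCCCCO)C(=O)O1`) reads > 10 ug/mL, which is a limit of the assay and not a number. Compound 4 (`CC(C)(C)C(=O)OCCCCCCCCCCCCCCC/C=C1\CC(CO)(COC(=O)C(C)(C)C)OC1=O`) differs from compound 3 by 4-(((tert-butyl)carbonyl)oxy)butyl in place of hydroxy on a saturated chain carbon, ten or more bonds along the chain from a double-bonded chain carbon. Two measured steps lead to the same hydroxy: an at least 2.1-fold higher number from compound 1 to compound 3 (0.33 log units; beyond the scatter) and an at least 3.3-fold higher number from compound 2 to compound 3 (0.52 log units; beyond the scatter). Compound 4 also lacks that hydroxy, although neither compound 1 nor compound 2 carries its ester, so a modest move to a lower number is expected. The expected change is an at least 2.0-fold lower number from compound 3 to compound 4 (0.30 log units; that floor lies within the scatter). Compound 4 is estimated at 5 ug/mL, with an expected range of 2 ug/mL to 12 ug/mL.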

Compound 4, concentration for 50% growth inhibition: 7.78 ug/mL
Estimate against measurement, compound 4: 1.6-fold (0.19 log units) below, within the range that was stated.
By their numbers in this assay, from the lowest: compounds 2, 1 and 4 (each within the scatter of the next, the first and the last beyond it). At a limit, above all of these: compound 3.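

In this assay compound 3 stands at a limit of the assay, not a number: the limit of > 10 ug/mL in this assay, at which 1 of the 4 values shown sits. The step to the ester therefore reads only as a floor (an at least 1.2-fold lower number from compound 3 to compound 4 (0.10 log units; that floor lies within the scatter)) and alone fixes no gain. The firmer comparison is with the methyl ether (a 1.7-fold higher number from compound 1 to compound 4 (0.22 log units; within the scatter)): (tert-butyl)carbonyl and methyl on the chain-end oxygen read alike, and among the four compounds only the free hydroxy sits at the limit. On these data alone, whether an amine or a carboxylic acid at the chain end would read with the hydroxy or with the ethers and the ester stays open.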